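The source may hold more compounds than are shown below. What is called first, only, known or untested is meant among the compounds shown, and "the series" means these compounds.

Compound 1 `CCCCCCCCCCCC[C@@H](O)[C@H]1CC[C@H]([C@H](O)CCCCCCCCCCNC(=O)c2ccnn2C)O1`: 77600 nM
Compound 2 `CCCCCCCCCCCC[C@@H](O)[C@H]1CC[C@H]([C@H](O)CCCCCCCCCCC(=O)Nc2ccnn2C)O1`: 100000 nM

For the measured compounds named here, in a functional assay on OVCAR-3 cells (Homo sapiens) for inhibition, read by sulforhodamine B assay, with a stated time of 48 h (a lower number here means a stronger inhibitor of growth, a higher number a weaker inhibitor of growth), compound 1 stands level with compound 2, the only other compound measured, as the two numbers lie within the scatter of each other. Compound 3 `CCCCCCCCCCCC[C@@H](O)[C@H]1CC[C@H]([C@H](O)CCCCCCCCCCOC(=O)c2ccnn2C)O1` departs from compound 1 at one place: ((1-methyl-1H-pyrazol-5-yl)carbonyl)oxy in place of ((1-methyl-1H-pyrazol-5-yl)carbonyl)amino on a saturated chain carbon, ten or more bonds along the chain from an oxygen on a saturated carbon and a saturated ring carbon. Going by the values given here, the one measured step that bears on this, a 1.3-fold higher number from compound 1 to compound 2 (0.11 log units; within the scatter), alters the same link but does not introduce the ((1-methyl-1H-pyrazol-5-yl)carbonyl)oxy group. On that thin evidence, no change beyond the scatter is expected, and no direction can be favoured. The expected step is a 1.1-fold lower number from compound 1 to compound 3 (0.04 log units; within the scatter). Compound 3 is estimated at 70000 nM, with an expected range of 25000 nM to 130000 nM.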

Compound 3, concentration for 50% growth inhibition: 100000 nM
For compound 3 the middle estimate is 1.4-fold (0.15 log units) below the measured one; the measured number falls inside the stated range.
By their numbers in this assay, from the lowest: compounds 1, 2 and 3 (each within the scatter of the next).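

Compound 3 adds a third link at this place on the chain, and in this assay the ((1-methyl-1H-pyrazol-5-yl)carbonyl)oxy group stands level with both amide-linked forms: (a 1.3-fold higher number from compound 1 to compound 3 (0.11 log units; within the scatter)) and (no change at the digits printed from compound 2 to compound 3 (within the scatter)). The loss of the amide hydrogen thus brings no change beyond the scatter in these compounds. No supporting data bear on why this is so.

From the compounds shown here alone, it remains open whether the 1-methyl-1H-pyrazol-5-yl ring itself matters in this assay. A carboxylic acid, an amine or a longer chain at this place also remains untested in the compounds shown here.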